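This account rests on a few compounds, and the source may have more. Where it says the series, first, only, none or still open, it means among the compounds named here.

Values measured in a functional assay on HCT-116 cells (Homo sapiens) for inhibition, read by sulforhodamine B assay, with a stated time of 48 h, tested at 50 uM; on this read-out higher numbers stand for more inhibition of growth at the one concentration tested and lower numbers for less inhibition of growth:
- Compound 1 `COc1ccc(/C=C/C(=O)/C=C/c2ccc(OCc3cn(CCCCOc4cc(=O)oc5ccccc45)nn3)c(OC)c2)cc1OC`: 55%
- Compound 2 `COc1cc(/C=C/C(=O)/C=C/c2ccco2)ccc1OCc1cn(CCCCOc2cc(=O)oc3ccccc23)nn1`: 47%
- Compound 3 `COc1cc(/C=C/C(=O)/C=C/c2cc(OC)c(OC)c(OC)c2)ccc1OCc1cn(CCCCOc2cc(=O)oc3ccccc23)nn1`: 63%

Compound 3 and compound 1 form the upper end of this small set, and only compound 2 is clearly separated from compound 3. That separation is the step of a number 16 percentage points higher from compound 2 to compound 3 (beyond the scatter), where 3,4,5-trimethoxyphenyl stands in place of furan-2-yl. The gap at the top is smaller, the step of a number 8 percentage points higher from compound 1 to compound 3 (within the scatter), where methoxy stands in place of hydrogen on an aromatic carbon.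

Compound 4 `COc1ccc(/C=C/C(=O)/C=C/c2ccc(OCc3cn(CCCCOc4cc(=O)oc5ccccc45)nn3)c(OC)c2)cc1` has not yet been measured. Relative to compound 3 it carries 4-methoxyphenyl in place of 3,4,5-trimethoxyphenyl on a double-bonded chain carbon bound to a double-bonded chain carbon. Among the measured compounds shown here, no measured compound carries this group, so the comparison is indirect. The step involving methoxy suggests that a change on this aryl group moves this assay only a little. The step involving furan-2-yl, a larger replacement, marks the widest change seen at this place. For the measured compounds named here, a small drop is therefore expected, with no step clearly beyond the scatter. The expected step is a number 8 percentage points lower from compound 3 to compound 4 (within the scatter). For compound 4 the estimated value is 55%, within an expected range from 42% to 67%.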

Compound 4, percent growth inhibition at one concentration: 40%
Compound 4: middle estimate off by 15 percentage points, on the high side; the measured number lies below the stated range.
By their numbers in this assay, from the lowest: compounds 4, 2, 1 and 3 (each within the scatter of the next, the first and the last beyond it).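

In this assay, among the compounds shown here, the aryl group on a double-bonded chain carbon bound to a double-bonded chain carbon proves more sensitive to its methoxy groups than the earlier compounds indicated: 4-methoxyphenyl in place of 3,4,5-trimethoxyphenyl gives the widest step yet seen at this place (a number 23 percentage points lower from compound 3 to compound 4 (beyond the scatter)), and hydrogen in place of methoxy on an aromatic carbon also gives a step beyond the scatter (a number 15 percentage points lower from compound 1 to compound 4 (beyond the scatter)), unlike the earlier methoxy step between compound 1 and compound 3. The six-membered aromatic ring alone does not separate these compounds from the furan-2-yl compound, as the remaining step lies within the scatter (a number 7 percentage points lower from compound 2 to compound 4 (within the scatter)). No measurement given here accounts for these differences.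

The compounds shown carry only methoxy groups on this phenyl ring, so they leave open whether a hydroxy group, a chlorine atom or a dimethylamino group on that ring would give a similar number. With growth inhibition read at a single concentration, they also leave open how far these steps would hold across a range of concentrations.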